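A few compounds are considered here, and "the series" means these few. Any claim that something is new, unique, unknown or untested is made for them only; others in the source may bear on it.

Measured in an assay on isolated protein for inhibition of 5-hydroxytryptamine receptor 4 (Homo sapiens); a higher number here means a weaker inhibitor, a lower number a stronger inhibitor:
- compound 1 `CC(C)N1CCN(S(=O)(=O)CCCN2CCC(CNC(=O)c3cccc4c3OCCO4)CC2)CC1`: 0.0316 nM
- compound 2 `O=C(NCC1CCN(CCCS(=O)(=O)N2CCN(Cc3cccnc3)CC2)CC1)c1cccc2c1OCCO2`: 0.159 nM
- compound 3 `CS(=O)(=O)N1CCN(S(=O)(=O)CCCN2CCC(CNC(=O)c3cccc4c3OCCO4)CC2)CC1`: 0.316 nM

Compound 3 gives the highest number of the three in this assay. The step of a 10-fold higher number from compound 1 to compound 3 (1.00 log units; beyond the scatter) is beyond the scatter, whereas a 2.0-fold higher number from compound 2 to compound 3 (0.30 log units; within the scatter) is within it; the step of a 5.0-fold higher number from compound 1 to compound 2 (0.70 log units; beyond the scatter) is modest. All three compounds differ only in the group on the same ring nitrogen.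

Compound 4 `CC(=O)N1CCN(S(=O)(=O)CCCN2CCC(CNC(=O)c3cccc4c3OCCO4)CC2)CC1` carries acetyl in place of methylsulfonyl on an amine nitrogen in a ring. Among the compounds with values here, no measured step swaps methylsulfonyl for acetyl, so the expectation rests only on the narrow spread across the three substituents already seen. A step within the scatter, or a slightly lower number, is expected for compound 4, estimated as a 1.6-fold lower number from compound 3 to compound 4 (0.20 log units; within the scatter). The estimate for compound 4 in this assay is 0.2 nM, with a range from 0.05 nM to 0.8 nM.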

Compound 4, inhibition constant: 0.126 nM
The estimate for compound 4 lay 1.6-fold (0.20 log units) above the measured number; low and high end bracket the measured number.
By their numbers in this assay, from the lowest: compound 1; then compounds 4, 2 and 3 (each within the scatter of the next, the first and the last beyond it).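

In this assay, acetyl in place of methylsulfonyl on this ring nitrogen gives a 2.5-fold lower number from compound 3 to compound 4 (0.40 log units; beyond the scatter) and so separates two uncharged groups without a ring. The same group gives a 1.3-fold lower number from compound 2 to compound 4 (0.10 log units; within the scatter) against (pyridin-3-yl)methyl and a 4.0-fold higher number from compound 1 to compound 4 (0.60 log units; beyond the scatter) against isopropyl, which leaves isopropyl alone at the low end of this set. No available data explain these differences.

Still open, as far as these compounds go, is whether a larger alkyl group such as tert-butyl or cyclohexyl would hold the low number seen with isopropyl. A carboxylic acid on a short chain at this nitrogen also remains untested in the compounds shown here.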